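Replacing 4-(trifluoromethyl)phenyl with 2-fluorophenyl in compound 3

The compounds below may be only part of what the source reports. "The series", "measured", "known", "first", "only" and "open" are said of these compounds alone.

In a functional assay on HeLa cells (Homo sapiens) for cytotoxicity, read by MTT assay, with a stated time of 48 h (a lower number here means a stronger inhibitor, a higher number a weaker inhibitor), compound 3 `O=C(O)CN1C(=O)/C(=C/c2nc3ccccc3n2Cc2ccc(C(F)(F)F)cc2)SC1=S` gives 21400 nM and sits level with compound 2 `O=C(O)CN1C(=O)/C(=C/c2nc3ccccc3n2Cc2ccc([N+](=O)[O-])cc2)SC1=S` at 18600 nM within the scatter. For compound 1 `O=C(O)CN1C(=O)/C(=C/c2nc3ccccc3n2Cc2ccc(Br)cc2F)SC1=S` the reading > 50000 nM is a limit of the assay. Compound 4 `O=C(O)CN1C(=O)/C(=C/c2nc3ccccc3n2Cc2ccccc2F)SC1=S` brings one change from compound 3 (2-fluorophenyl in place of 4-(trifluoromethyl)phenyl on a saturated chain carbon bound to an aromatic nitrogen). For the measured compounds named here, two measured steps bear on it: an at least 2.3-fold lower number from compound 1 to compound 3 (0.36 log units; beyond the scatter) and an at least 2.6-fold lower number from compound 1 to compound 2 (0.42 log units; beyond the scatter) both leave 4-bromo-2-fluorophenyl, the group whose name comes closest to 2-fluorophenyl. Swapping nitro for trifluoromethyl, a 1.2-fold higher number from compound 2 to compound 3 (0.06 log units; within the scatter) stays within the scatter. A small rise in the number is therefore expected (a 1.5-fold higher number from compound 3 to compound 4 (0.17 log units; within the scatter)). Compound 4 is estimated at 32000 nM (expected range 16000 nM to 50000 nM).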

Compound 4, half-maximal inhibitory concentration: 640 nM
Estimate against measurement, compound 4: 50-fold (1.70 log units) above, outside the stated range (below it).
By their numbers in this assay, from the lowest: compound 4; then compounds 2 and 3 (each within the scatter of the next). At a limit, above all of these: compound 1.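

Putting 2-fluorophenyl on the saturated chain carbon bound to an aromatic nitrogen gives a 33-fold lower number from compound 3 to compound 4 (1.52 log units; beyond the scatter) and a 29-fold lower number from compound 2 to compound 4 (1.46 log units; beyond the scatter), so this position can move the number far, although compound 2 and compound 3 sat level. Hydrogen in place of bromo alone gives an at least 78-fold lower number from compound 1 to compound 4 (1.89 log units; beyond the scatter), showing that one aromatic substituent can matter greatly here. That step starts from a limit of the assay, so its true size stays unknown: the limit of > 50000 nM in this assay, at which 1 of the 4 values shown sits.

From the compounds shown here alone, whether the fluorine matters remains open, and a plain phenyl group would test this. Also open, going by these compounds, is how a 2-chlorophenyl group or a longer chain would behave here.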